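Swapping the Amide Tail on a Spiro Scaffold

The source may report more compounds than this note shows. Statements on the series, on what has been measured and on what is new or still open speak of the compounds shown alone.

Measured so far:
compound 1 `CC(C)(C)c1ccc(C(=O)N2CCC3(CC2)C(=O)N(CC(=O)N2CCNCC2)CN3c2ccccc2)cc1` — 22000 nM
compound 2 `CC(C)(C)c1ccc(C(=O)N2CCC3(CC2)C(=O)N(CC(=O)NCCCNS(C)(=O)=O)CN3c2ccccc2)cc1` — 10400 nM

In an assay on HEK293 cells for displacement of a labelled ligand from NPC1-like intracellular cholesterol transporter 1 (Homo sapiens) (on this read-out lower numbers stand for stronger inhibition and higher numbers for weaker inhibition), compound 1 gives 22000 nM, and compound 2 gives 10400 nM, the lowest of the two numbers. Among the compounds with values here, the one measured step, a 2.1-fold lower number from compound 1 to compound 2 (0.33 log units; beyond the scatter), is modest but beyond the scatter.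

Compound 3 `CC1CCCN(C(=O)CN2CN(c3ccccc3)C3(CCN(C(=O)c4ccc(C(C)(C)C)cc4)CC3)C2=O)C1` is not yet measured. It differs from compound 2 as follows: 3-methylpiperidin-1-yl in place of (3-(methanesulfonamido)propyl)amino on a carbonyl carbon. Within the data shown here, the only step in hand concerns a different exchange on the same carbonyl carbon, so it bears on compound 3 only loosely: a ring without donors or acceptors now enters where a chain with two of each leaves, and the earlier step shows that this position tolerates change of that size without a large shift.

Compound 3 is therefore expected to land near compound 2, with a step of a 1.2-fold higher number from compound 2 to compound 3 (0.06 log units; within the scatter), well inside the scatter. The estimate for compound 3 is 12000 nM, with a range from 4000 nM to 40000 nM.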

Compound 3, half-maximal inhibitory concentration: 12000 nM
Beside the measured number, compound 3's estimate shows no gap at the digits printed, within the range that was stated.
By their numbers in this assay, from the lowest: compounds 2, 3 and 1 (each within the scatter of the next, the first and the last beyond it).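

In this assay, the step of a 1.2-fold higher number from compound 2 to compound 3 (0.06 log units; within the scatter) lies within the scatter, so the ring-bearing 3-methylpiperidin-1-yl, with 0 hydrogen-bond donors and 0 acceptors, cannot be told apart from the open-chain (3-(methanesulfonamido)propyl)amino group. The step of a 1.8-fold lower number from compound 1 to compound 3 (0.26 log units; within the scatter) also lies within the scatter, so compound 3 cannot be told apart from compound 1 either, although compound 1 and compound 2 are separated by slightly more than the scatter. No supporting measurement offers an explanation for these results.

From the compounds shown here alone, it remains open whether a carboxylic acid or a longer chain on this carbonyl carbon would give a clearly different number. The compounds shown also leave open what a plain piperidin-1-yl, lacking the methyl group, would give.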